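A few compounds are considered here, and "the series" means these few. Any claim that something is new, unique, unknown or untested is made for them only; others in the source may bear on it.

Three analogues of the shared core have been measured in an ADME assay on MDCK cells (Canis lupus familiaris) for cytotoxicity; on this read-out lower numbers stand for higher toxicity in this test and higher numbers for lower toxicity in this test. Compound 1 `CSc1nc2n(n1)C(c1ccc(O)c(O)c1)C([N+](=O)[O-])=NN2` gives 362000 nM in this assay, compound 2 `O=[N+]([O-])C1=CNc2nc(C(F)(F)F)nn2C1c1c(O)cc(O)cc1O` gives 838000 nM, and compound 3 `O=[N+]([O-])C1=NNc2ncnn2C1c1c(O)cc(O)cc1O` gives 119000 nM. Compound 3 stands lowest of the three; compound 1 is nearest, with a number beyond the scatter, and compound 2 is furthest, also beyond the scatter.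

Compound 4 `CSc1nc2n(n1)C(c1c(O)cc(O)cc1O)C([N+](=O)[O-])=NN2` has not yet been measured. It differs from compound 3 by methylsulfanyl in place of hydrogen on an aromatic carbon. Among the measured compounds shown here, no directly comparable pair among the measured compounds isolates this change, so the step can only be gauged loosely. Compound 1, which also carries methylsulfanyl at this position but a different phenyl substitution, gives 362000 nM, and compound 2, with trifluoromethyl there, gives 838000 nM; both sit higher than compound 3.

The step from a 2.5-fold higher number from compound 3 to compound 4 (0.40 log units; beyond the scatter) is therefore expected to be modest and upward, possibly no larger than the scatter. Compound 4 is estimated at 300000 nM, with a range of 110000 nM to 850000 nM.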

Compound 4, half-maximal cytotoxic concentration: 877000 nM
Compound 4: middle estimate off by 2.9-fold (0.47 log units), on the low side; the whole stated range lies below it.
By their numbers in this assay, from the lowest: compound 3; then compound 1; then compounds 2 and 4 (each within the scatter of the next).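

In this assay, among the compounds shown here, methylsulfanyl in place of hydrogen on an aromatic carbon gives a 7.4-fold higher number from compound 3 to compound 4 (0.87 log units; beyond the scatter), the first direct reading of a change at this position; the earlier compounds differed in more than one place. With the rest of the structure held constant, this single change on the five-membered aromatic ring, between two ring nitrogen atoms, moves the read-out towards lower toxicity in this test. Nothing on hand accounts for the size or direction of this step.

From the compounds shown here alone, whether the same step holds with the phenyl substitution of compound 1 remains open, and trifluoromethyl cannot be read against methylsulfanyl, since compound 2 differs from compound 4 in more than one place. Going by these compounds, how an amine, a carboxylic acid or a longer chain would read at this position also remains open.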